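A few compounds are considered here, and "the series" means these few. Any claim that something is new, unique, unknown or untested is made for them only; others in the source may bear on it.

Of the compounds shown here, three sharing one core have numbers so far in a physicochemical assay for lipophilicity, using the shake flask method, in phosphate buffer, measured as octanol-water partition, with a stated time of 24 h, at pH 7.4; a lower number here means a more polar compound, a higher number a more lipophilic compound: compound 1 (`Cc1cc(C2CS(=O)(=O)Oc3c2c(C2CC2)nn3-c2ccccc2Cl)ccc1Br`) gives 2.53, compound 2 (`O=S1(=O)CC(c2ccc(F)cc2)c2c(C3CC3)nn(-c3ccccc3F)c2O1`) gives 1.76 and compound 3 (`COc1cccc(C2CS(=O)(=O)Oc3c2c(C2CC2)nn3-c2ccccc2F)c1`) gives 2.01. Compound 2 stands at the low end of this short range, within the scatter of compound 3 and beyond the scatter from compound 1.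

Compound 4 (`O=S1(=O)CC(c2ccc(F)cc2)c2c(C3CC3)nn(-c3ccccc3Cl)c2O1`) is reached from compound 2 by a single change: chloro in place of fluoro on an aromatic carbon. In short, 2-fluorophenyl becomes 2-chlorophenyl.

For the measured compounds named here, no measured step isolates this swap. Going by the values given here, the one single-place step available, a number 0.25 log units higher from compound 2 to compound 3 (within the scatter), concerns a group on a saturated ring carbon, a different place, and offers no direct size for this change. Among the compounds with values here, compound 1, at 2.53, is the only measured compound carrying the 2-chlorophenyl group, whereas compound 2 gives 1.76. However, compound 1 also differs on the saturated ring carbon, so that gap cannot be divided between the two places.

A modest upward step in this assay is therefore expected, near the edge of the scatter, with wide uncertainty. The estimated change is a number 0.34 log units higher from compound 2 to compound 4 (beyond the scatter). For compound 4 the expected value is 2.1, with an estimated range of 1.8 to 2.45.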

Compound 4, partition coefficient: 2.04
For compound 4 the middle estimate is 0.06 log units above the measured one; low and high end bracket the measured number.
By their numbers in this assay, from the lowest: compounds 2, 3 and 4 (each within the scatter of the next); then compound 1.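

In this assay, for the compounds shown here, the only step read at this position so far, 2-fluorophenyl to 2-chlorophenyl on an aromatic carbon, gives a number 0.28 log units higher from compound 2 to compound 4 (within the scatter) and so does not separate the two halogens when 4-fluorophenyl sits on the saturated ring carbon. Going by these compounds alone, with 2-chlorophenyl held fixed, the saturated ring carbon can now be read on its own: 4-fluorophenyl in place of 4-bromo-3-methylphenyl gives a number 0.49 log units lower from compound 1 to compound 4 (beyond the scatter) and, unlike the halogen swap, clears the scatter, which is the first separation of that place from the aromatic one. No supporting data bear on why either step has the size it has.

The compounds shown leave open whether the halogen swap stays within the scatter when 3-methoxyphenyl or 4-bromo-3-methylphenyl occupies the saturated ring carbon, since each of those groups appears here with only one of the two halogens. Also open, going by these compounds, is how far the number in this assay would move with a group of another kind on this aromatic carbon, such as an amine, a carboxylic acid or a longer chain, as only fluoro and chloro appear there.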